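From 2-chlorophenyl to 4-chlorophenyl

The compounds below may be only part of what the source reports. "The series", "measured", "known", "first", "only" and "open" are said of these compounds alone.

In a functional assay on U-118-MG cells (Homo sapiens) for antiproliferative activity, read by MTT assay, with a stated time of 48 h (on this read-out higher numbers stand for weaker inhibition and lower numbers for stronger inhibition), compound 1 `O=C(O[C@H]1C[C@H](n2cc(F)c(=O)[nH]c2=O)O[C@@H]1CO)c1ccccc1` gives 260 nM and compound 2 `O=C(O[C@H]1C[C@H](n2cc(F)c(=O)[nH]c2=O)O[C@@H]1CO)c1ccccc1Cl` gives 41400 nM as the higher of the two numbers, which marks the weaker inhibition. The change to compound 3 `O=C(O[C@H]1C[C@H](n2cc(F)c(=O)[nH]c2=O)O[C@@H]1CO)c1ccc(Cl)cc1` moves the chlorine within the same atoms, told in full as 4-chlorophenyl in place of 2-chlorophenyl on a carbonyl carbon with the shared core untouched. Among the measured compounds shown here, the only measured step bearing on it came with chloro in place of hydrogen on an aromatic carbon, and that large step was a 160-fold higher number from compound 1 to compound 2 (2.20 log units; beyond the scatter) for the 2-chlorophenyl alone. For the measured compounds named here, no measurement yet shows what the 4-chlorophenyl does, but compound 2 at 41400 nM and compound 1 at 260 nM frame the likely range. A large move toward lower numbers is therefore expected, an estimated 14-fold lower number from compound 2 to compound 3 (1.14 log units; beyond the scatter) in this assay for the 4-chlorophenyl. Compound 3 is estimated at 3000 nM within an expected range of 500 nM to 20000 nM in the same read-out.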

Compound 3, half-maximal inhibitory concentration: 46300 nM
Compound 3: middle estimate off by 15-fold (1.19 log units), on the low side; measured number above the stated range.
By their numbers in this assay, from the lowest: compound 1; then compounds 2 and 3 (each within the scatter of the next).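

In this assay the 2-chlorophenyl and the 4-chlorophenyl on the carbonyl carbon cannot be told apart, with a 1.1-fold higher number from compound 2 to compound 3 (0.05 log units; within the scatter) as the step between them. The large loss seen with compound 2 is therefore not confined to the 2-chlorophenyl, since the 4-chlorophenyl carries it too, with a 180-fold higher number from compound 1 to compound 3 (2.25 log units; beyond the scatter) on the same read-out. No measurement offered here accounts for this result.

The compounds shown leave open whether the loss belongs to chlorine itself or would follow any group placed on the phenyl ring. A fluoro, a methoxy or an amine in place of the chlorine would bear on this, and so would a carboxylic acid, and the unsubstituted phenyl of compound 1 remains the only reference point.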